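From 1H-imidazol-1-yl to pyrimidin-5-yl on compound 2

This account rests on a few compounds, and the source may have more. Where it says the series, first, only, none or still open, it means among the compounds named here.

Measured in a functional assay on VCaP cells (Homo sapiens) for antiproliferative activity, read by CCK-8 assay, with a stated time of 6 days; a higher number here means a weaker inhibitor, a lower number a stronger inhibitor:
- compound 1 `CCN(c1ccc(C#N)c(Cl)c1)c1cc(-c2cncnc2)ccc1C`: 3920 nM
- compound 2 `CCN(c1cccc(-n2ccnc2)c1)c1ccc(C#N)c(Cl)c1`: > 30000 nM (a limit)

Compound 2 gives only a limit, > 30000 nM, and no number.

Compound 3 `CCN(c1cccc(-c2cncnc2)c1)c1ccc(C#N)c(Cl)c1` carries pyrimidin-5-yl in place of 1H-imidazol-1-yl on an aromatic carbon. For the measured compounds named here, no measured step isolates this change. Compound 1, which also bears pyrimidin-5-yl, gives 3920 nM in this assay, so compound 3 is expected to inhibit more strongly than compound 2. The expected change is an at least 3.7-fold lower number from compound 2 to compound 3 (0.57 log units; beyond the scatter). For compound 3 the estimated value is 8000 nM, with an expected range of 2500 nM to 25000 nM.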

Compound 3, half-maximal inhibitory concentration: > 30000 nM
Compound 3: only a limit was reported; the forecaster's own chance of this, stated with the estimate: 15%; middle value at least 3.7-fold (0.57 log units) away from the limit.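

In this assay, hydrogen in place of methyl on an aromatic carbon gives an at least 7.6-fold higher number from compound 1 to compound 3 (0.88 log units; beyond the scatter). With pyrimidin-5-yl held constant, the methyl of compound 1 therefore marks the difference between a measurable value and none. Pyrimidin-5-yl in place of 1H-imidazol-1-yl cannot be read, because compound 2 and compound 3 each give a limit and not a number: the limit of > 30000 nM in this assay, at which 2 of the 3 values shown sit.

Still open, from the compounds shown here alone, is whether ethyl, methoxy or chlorine on that aromatic carbon would serve as the methyl does. Also open, going by these compounds, is whether 1H-imidazol-1-yl paired with that methyl would give a number in this assay.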